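This account rests on a few compounds, and the source may have more. Where it says the series, first, only, none or still open, it means among the compounds named here.

Series notes. Among the measured compounds shown here, compound 1 `Cc1ccccc1C(=O)NCc1ccc(CNS(=O)(=O)c2ccccc2C)cc1` is the only compound carrying 2-methylphenyl on the sulfonyl sulfur; in an assay on MDA-MB-231 cells for displacement of a labelled ligand from C-X-C chemokine receptor type 4 (Homo sapiens), read by fluorescence and microscopy, with stated times of 10 min and 30 min (on this read-out lower numbers stand for an effect already at smaller amounts and higher numbers for an effect only at larger amounts of compound), compound 1 gives 10 nM. Compound 2 `COc1ccccc1C(=O)NCc1ccc(CNS(=O)(=O)c2cccc(Cl)c2)cc1` gives 1000 nM and compound 3 `COc1ccccc1C(=O)NCc1ccc(CNS(=O)(=O)c2ccc(F)cc2)cc1` gives 100 nM, so compound 3 stands second highest of the three numbers, between compound 1 and compound 2. For the measured compounds named here, the only step measured so far is a 10-fold lower number from compound 2 to compound 3 (1.00 log units; beyond the scatter), an exchange of the aryl on the sulfonyl sulfur, as is the step to compound 4 `COc1ccccc1C(=O)NCc1ccc(CNS(=O)(=O)c2ccccc2C)cc1`: 2-methylphenyl in place of 4-fluorophenyl on a sulfonyl sulfur. Compound 1 and compound 4 share the 2-methylphenyl but differ elsewhere, so compound 1 gives only a loose pointer. Given the number for compound 1 at 10 nM, compound 4 is expected at 20 nM (range 5 nM to 100 nM), an expected step of a 5.0-fold lower number from compound 3 to compound 4 (0.70 log units; beyond the scatter).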

Compound 4, effective concentration (reported as EC, without a stated level of effect): 1000 nM
Beside the measured number, compound 4's estimate is 50-fold (1.70 log units) below it, outside the stated range (above it).
By their numbers in this assay, from the lowest: compound 1; then compound 3; then compounds 2 and 4 (each within the scatter of the next).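

With methoxy on the aromatic carbon, 2-methylphenyl on the sulfonyl sulfur brings no gain: this assay shows a 10-fold higher number from compound 3 to compound 4 (1.00 log units; beyond the scatter) against 4-fluorophenyl and no change at the digits printed from compound 2 to compound 4 (within the scatter) against 3-chlorophenyl. With 2-methylphenyl held constant, methoxy in place of methyl on an aromatic carbon gives a 100-fold higher number from compound 1 to compound 4 (2.00 log units; beyond the scatter) as the result, so the sulfonyl aryl cannot be read apart from that other place. No evidence on hand accounts for these steps.

Still open, on these data alone, is whether 4-fluorophenyl keeps its lower number with methyl in place of methoxy. Also open, as far as these compounds go, is how an amine or a carboxylic acid on the sulfonyl aryl would read.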